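A nitrile replaces a methyl on the sulfonyl arene

This account rests on a few compounds, and the source may have more. Where it says the series, first, only, none or still open, it means among the compounds named here.

Two compounds have been measured in an assay on isolated protein for displacement of a labelled ligand from metabotropic glutamate receptor 5 (Homo sapiens), with a stated time of 60 min, tested at 1 uM; on this read-out lower numbers stand for less inhibition and higher numbers for more inhibition at the one concentration tested (going by the name of the read-out):
compound 1 `CC1CCN(c2c(S(=O)(=O)c3ccccc3)cnc3cc(Cl)ccc23)CC1` gives 93%
compound 2 `Cc1ccc(S(=O)(=O)c2cnc3cc(Cl)ccc3c2N2CCC(C)CC2)cc1` gives 94%

Compound 2 stands within the usual scatter of compound 1, so the two numbers cannot be told apart. Within the data shown here, the one measured step, a number 1 percentage points higher from compound 1 to compound 2 (within the scatter), is methyl in place of hydrogen on an aromatic carbon, and the read-out barely moved.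

Compound 3 `CC1CCN(c2c(S(=O)(=O)c3cccc(C#N)c3)cnc3cc(Cl)ccc23)CC1` has not yet been measured. It differs from compound 2 in one place: 3-cyanophenyl in place of 4-methylphenyl on a sulfonyl sulfur. Among the measured compounds shown here, the only step that bears on this change is a number 1 percentage points higher from compound 1 to compound 2 (within the scatter), which also altered the aryl group on the sulfonyl sulfur and stayed within the scatter. For the measured compounds named here, no compound with a nitrile has been measured, so the judgement rests on that step alone. The step of a number 4 percentage points lower from compound 2 to compound 3 (within the scatter) is therefore expected to remain within the scatter. Compound 3 is estimated to give 90%, with a range from 75% to 98%.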

Compound 3, a percentage reported as inhibition, at one concentration (the size of the read-out at that concentration, not a potency): 94%
Beside the measured number, compound 3's estimate is 4 percentage points below it, within the range that was stated.
By their numbers in this assay, from the lowest: compounds 1, 2 and 3 (each within the scatter of the next).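

With the nitrile in place, this assay gives no change at the digits printed from compound 2 to compound 3 (within the scatter) for the swap of 4-methylphenyl for 3-cyanophenyl on a sulfonyl sulfur. Set against the plain phenyl group, the nitrile gives a number 1 percentage points higher from compound 1 to compound 3 (within the scatter) and so, like the methyl group before it, leaves the number inside the scatter, now with a group that carries a triple bond and a hydrogen-bond acceptor. No measurement shown offers a reason for this flat result.

All three numbers lie close together near the top of the percentage scale, and a reading at one concentration is not a potency, so real differences among these aryl groups could stay hidden. From the compounds shown here alone, whether a carboxylic acid, an amine or a longer alkyl chain on this aryl group would also leave the number in place remains open.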